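Benzoyl for 4-fluorobenzyl on a sulfoxide piperidine

The compounds below may be only part of what the source reports. "The series", "measured", "known", "first", "only" and "open" are said of these compounds alone.

For the measured compounds named here, compound 1 `[O-][S+](CCNC1CCN(Cc2ccc(F)cc2)CC1)C(c1ccc(F)cc1)c1ccc(F)cc1` is one of two compounds measured in an assay on membranes from striatum (strain Sprague-Dawley) for displacement of a labelled ligand from sodium-dependent dopamine transporter (Rattus norvegicus), read by scintillation counting, with a stated time of 120 min (on this read-out lower numbers stand for stronger inhibition and higher numbers for weaker inhibition), where compound 1 gives 50.6 nM. Compound 2 `O=C(c1ccc(F)cc1)N1CCC(NCCSC(c2ccc(F)cc2)c2ccc(F)cc2)CC1` gives 7.04 nM in this assay. Going by the values given here, of these two numbers, that of compound 1 is the higher one, and the gap between the two values lies beyond the scatter of repeated measurements; compound 2 differs from compound 1 in more than one place, so no single step links them.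

Compound 3 `O=C(c1ccccc1)N1CCC(NCC[S+]([O-])C(c2ccc(F)cc2)c2ccc(F)cc2)CC1` has not yet been measured. It differs from compound 1 in one place: benzoyl in place of 4-fluorobenzyl on an amine nitrogen in a ring. Because compound 2, which also carries an acyl group on the ring nitrogen, gives 7.04 nM, a move toward a lower number is expected for compound 3, though compound 3 keeps the sulfoxide of compound 1 rather than the sulfide of compound 2. The step of a 2.5-fold lower number from compound 1 to compound 3 (0.40 log units; beyond the scatter) is therefore estimated to be a modest one, close to the edge of the scatter. Compound 3 is expected to give 20 nM in this assay, with a range from 6 nM to 60 nM.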

Compound 3, inhibition constant: 79.1 nM
Estimate against measurement, compound 3: 4.0-fold (0.60 log units) below; measured number outside the range, above it.
By their numbers in this assay, from the lowest: compound 2; then compounds 1 and 3 (each within the scatter of the next).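

In this assay, benzoyl in place of 4-fluorobenzyl on the amine nitrogen in the ring gives a 1.6-fold higher number from compound 1 to compound 3 (0.19 log units; within the scatter) and so leaves the reading within the scatter, which shows that at this position, with the sulfoxide kept, the two groups cannot be told apart. The exchange is not an empty one on paper: the heavy-atom count stays the same, but the fluorine leaves and a carbonyl enters, bringing a hydrogen-bond acceptor, and this gives no measurable shift here. Thus a carbonyl on this ring nitrogen does not by itself bring a lower number when the sulfoxide is present, something the two earlier compounds could not show, and no measurement at hand accounts for this outcome.

The step changes the fluorine and the carbonyl together, so the contribution of each stays unresolved, and the part played by the sulfur in its sulfoxide or sulfide form cannot be read from single changes among these compounds. Also open, as far as these compounds go, is how a plain benzyl or an acetyl group on the same ring nitrogen would read, and whether a 4-fluorobenzoyl group would behave like benzoyl when the sulfoxide is kept.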